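Trifluoromethyl Replacing Methyl at an Aromatic Oxygen

The source may report more compounds than this note shows. Statements on the series, on what has been measured and on what is new or still open speak of the compounds shown alone.

Compound 1 `COc1ccc(/C=C2\CCC=CC2=O)cc1` gives 1560 nM in a functional assay on KB cells (Homo sapiens) for antiproliferative activity, read by sulforhodamine B assay, with a stated time of 72 h; a lower number here means a stronger inhibitor, a higher number a weaker inhibitor. Compound 2 `COc1cccc(/C=C2\CCC=CC2=O)c1` gives 1550 nM in this assay, so compound 1 stands alongside compound 2, the two numbers lying within the usual scatter of each other. Compound 3 `O=C1C=CCC/C1=C\c1ccc(OC(F)(F)F)cc1` differs from compound 1 in one place: trifluoromethyl in place of methyl on an oxygen on an aromatic ring. For the measured compounds named here, no measured pair shows this change, so nothing beyond the scatter is expected in either direction in this assay. The step of a 1.0-fold lower number from compound 1 to compound 3 (0.02 log units; within the scatter) is estimated to be small. Compound 3 is expected to give 1500 nM in this assay, with a range from 600 nM to 4000 nM.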

Compound 3, half-maximal inhibitory concentration: 530 nM
Estimate against measurement, compound 3: 2.8-fold (0.45 log units) above; measured number below the stated range.
By their numbers in this assay, from the lowest: compound 3; then compounds 2 and 1 (each within the scatter of the next).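

In this assay, replacing methyl with trifluoromethyl on the oxygen on the aromatic ring gives a 2.9-fold lower number from compound 1 to compound 3 (0.47 log units; beyond the scatter) and so moves the number toward a stronger inhibitor. Compound 1 and compound 2 differ in more than this group and could not show that this oxygen substituent can change the number. Nothing measured here explains the change.

Only this one replacement at the oxygen is shown, so a longer chain such as ethyl or propyl might behave differently. From the compounds shown here alone, it also remains open whether trifluoromethoxy would lower the number of compound 2 in the same way.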